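Moving the methyl around the benzyl ring

The compounds below may be only part of what the source reports. "The series", "measured", "known", "first", "only" and "open" are said of these compounds alone.

Measured compounds:
- Compound 1 `COc1ccc(CN2CCC(CCNC(=O)/C=C/c3cc(C(C)(C)C)c(O)c(C(C)(C)C)c3)CC2)cc1`: 72500 nM
- Compound 2 `Cc1ccccc1CN1CCC(CCNC(=O)/C=C/c2cc(C(C)(C)C)c(O)c(C(C)(C)C)c2)CC1`: 69300 nM

Two analogues sharing one core have been tested in an assay on isolated protein for inhibition of Amine oxidase [flavin-containing] A (Homo sapiens), read by fluorescence, with stated times of 15 min and 20 min; a lower number here means a stronger inhibitor, a higher number a weaker inhibitor. Compound 1 gives 72500 nM, and compound 2 gives 69300 nM. Among the compounds with values here, the only measured step, a 1.0-fold lower number from compound 1 to compound 2 (0.02 log units; within the scatter), lies within the scatter, so the two stand level and neither can be called the stronger. Compound 2 therefore holds the lower of the two numbers, with compound 1 right beside it.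

Compound 3 `Cc1ccc(CN2CCC(CCNC(=O)/C=C/c3cc(C(C)(C)C)c(O)c(C(C)(C)C)c3)CC2)cc1` has not been measured. Its difference from compound 2 is 4-methylphenyl in place of 2-methylphenyl on a saturated chain carbon bound to an amine nitrogen in a ring. Within the data shown here, the one step that bears on this position, a 1.0-fold lower number from compound 1 to compound 2 (0.02 log units; within the scatter), showed that swapping the aryl group on that carbon left this assay unchanged. On that basis the step from compound 2 to compound 3 is expected to stay within the scatter, a 1.0-fold higher number from compound 2 to compound 3 (0.00 log units; within the scatter). Compound 3 is estimated at 70000 nM, with a range from 30000 nM to 160000 nM.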

Compound 3, half-maximal inhibitory concentration: 70100 nM
Compound 3: the middle estimate sits 1.0-fold (0.00 log units) below what was measured; the measured number falls inside the stated range.
By their numbers in this assay, from the lowest: compounds 2, 3 and 1 (each within the scatter of the next).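

Moving the methyl, from 2-methylbenzyl to 4-methylbenzyl with the same atoms joined differently, leaves this assay flat (a 1.0-fold higher number from compound 2 to compound 3 (0.00 log units; within the scatter)), so the place of the methyl on this aryl group makes no readable difference between these two compounds. The second step (a 1.0-fold lower number from compound 1 to compound 3 (0.01 log units; within the scatter)) isolates the group itself, with methyl in place of methoxy on an aromatic carbon, whereas the earlier pair changed both the group and its place at once, and this change also stays within the scatter. Nothing available explains why these aryl groups read alike.

From the compounds shown here alone, it remains open whether an amine or a carboxylic acid on this aryl group would move the number away from this level. Also open, going by these compounds, is whether a longer chain between the aryl group and the amine nitrogen in the ring would do so.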